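The source may report more compounds than this note shows. Statements on the series, on what has been measured and on what is new or still open speak of the compounds shown alone.

Measured so far:
compound 1 `CCOC(=O)c1[nH]c2cc(Cl)ccc2c1/C=N/NC(=O)Cc1cccs1` — > 10000 nM
compound 2 `CCOC(=O)c1[nH]c2cc(Cl)ccc2c1/C=N/NC(=O)CCCOc1ccc(Cl)cc1Cl` — > 10000 nM

The two measured compounds share one core and differ only in the group attached beyond the hydrazide carbonyl. In an assay for inhibition of Polyunsaturated fatty acid lipoxygenase ALOX15 (Homo sapiens), with a stated time of 8 min (on this read-out lower numbers stand for stronger inhibition and higher numbers for weaker inhibition), compound 1 gives > 10000 nM, which is a limit of the assay and not a number. In this assay compound 2 gives > 10000 nM, again a limit rather than a measured number. Both values thus sit at the limit of > 10000 nM in this assay, at which 2 of the 2 values shown sit, so compound 1 can be neither ranked above nor below compound 2 on these numbers; the two simply stand at the same limit.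

Compound 3 `CCOC(=O)c1[nH]c2cc(Cl)ccc2c1/C=N/NC(=O)COc1ccccc1` has not yet been measured. It differs from compound 1 by a single change: phenoxy in place of thiophen-2-yl on a saturated chain carbon bound to a carbonyl carbon. Among the compounds with values here, no step between measured compounds exists to show how much such a change can move this read-out, since both measured values are limits. The step from compound 1 to compound 3 is expected to be a step that the limit leaves unreadable from compound 1 to compound 3, that is, none beyond the usual scatter. Compound 3 is therefore estimated at 15000 nM, within a range from 5000 nM to 50000 nM, and is expected most likely to be reported as a limit as well.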

Compound 3, half-maximal inhibitory concentration: > 10000 nM
Compound 3 was reported as a limit (the forecaster's own chance of this, stated with the estimate: 80%); the middle value is on the limit's open side.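

In this assay compound 3 gives > 10000 nM, which is a limit and not a number. Compound 1 also stands at a limit, so no step from compound 1 to compound 3 can be read, and all the values share one ceiling: the limit of > 10000 nM in this assay, at which 3 of the 3 values shown sit.

The compounds shown leave open whether any group on the shared core gives a measurable inhibition value.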